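From methyl to methoxy on a shared core

The compounds below may be only part of what the source reports. "The series", "measured", "known", "first", "only" and "open" are said of these compounds alone.

Values measured in a functional assay on HUVEC cells (Homo sapiens) for inhibition, using NADPH, with a stated time of 2 h (a higher number here means a weaker inhibitor, a lower number a stronger inhibitor), so far
compound 1 `Cc1c(COc2ccnc(OCC3CCOCC3)c2)[nH]c2ccccc2c1=O` gives 43 nM
compound 2 `Cc1c(COc2cccc(OCC3CCOCC3)c2)[nH]c2ccc(C(=O)O)cc2c1=O` gives 400 nM
compound 3 `Cc1ccc2[nH]c(COc3cccc(OCC4CCOCC4)c3)c(C)c(=O)c2c1` gives 38 nM

Compound 3 sits at the low end of this short series. Its value of 38 nM lies within the scatter of compound 1 and well beyond the scatter from compound 2, so compound 3 and compound 1 cannot be told apart on these numbers.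

The next compound is compound 4 `COc1ccc2[nH]c(COc3cccc(OCC4CCOCC4)c3)c(C)c(=O)c2c1`, which carries methoxy in place of methyl on an aromatic carbon. The change is methoxy in place of methyl on an aromatic carbon and leaves the rest of compound 3 untouched.

Among the compounds with values here, one measured step bears on this aromatic carbon. It is an 11-fold lower number from compound 2 to compound 3 (1.02 log units; beyond the scatter) and it is large, for methyl in place of carboxy. That step shows that the number in this assay can move with the group at this place. However, it starts from a carboxy compound, and no measured pair compares methyl with methoxy. The swap from methyl to methoxy is a much smaller structural change than the one from carboxy to methyl, so no large shift is expected here.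

The expected result is a 1.2-fold higher number from compound 3 to compound 4 (0.07 log units; within the scatter) and thus no change beyond the scatter. Compound 4 is estimated at 45 nM (18 nM to 110 nM).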

Compound 4, half-maximal inhibitory concentration in the HUVEC assay: > 10000 nM
Compound 4: only a limit was reported (the forecaster's own chance of this, stated with the estimate: 3%); at least 220-fold (2.34 log units) between middle value and limit.
By their numbers in the HUVEC assay, from the lowest: compounds 3 and 1 (each within the scatter of the next); then compound 2. At a limit, above all of these: compound 4.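

In the HUVEC assay the swap of methyl for methoxy on this aromatic carbon gives an at least 260-fold higher number from compound 3 to compound 4 (2.42 log units; beyond the scatter), so a change far smaller than the loss of carboxy has the larger effect. Within the data shown here, in the HUVEC assay methoxy also falls short of carboxy at this place, with an at least 25-fold higher number from compound 2 to compound 4 (1.39 log units; beyond the scatter), which the earlier compounds could not show, and among compound 2, compound 3 and compound 4 the group order runs methyl, then carboxy, then methoxy, so the size of the change in structure does not track the size of the step. What compound 4 gives in the HUVEC assay is a limit and not a number, so the true size of both steps stays unknown beyond what is printed: the limit of > 10000 nM in the HUVEC assay, at which 1 of the 4 values shown sits.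

In a physicochemical assay for solubility, at pH 6.8 (a higher number here means a more soluble compound, a lower number a less soluble compound), compound 3 gives < 1000 nM, which is a limit and not a number. In the physicochemical assay compound 4 gives < 1000 nM, which is also a limit and not a number. The step between compound 3 and compound 4 in the physicochemical assay cannot be read, so these compounds say nothing on solubility at this place: the limit of < 1000 nM in the physicochemical assay, at which 2 of the 2 values shown sit. Still open is where a hydroxyl group, an ethyl group, an ethoxy chain or an amine at this aromatic carbon would fall relative to methyl and methoxy, and the compounds shown give no reason for the loss seen with methoxy.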